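Phenyl in place of methyl on the shared core

The source may report more compounds than this note shows. Statements on the series, on what has been measured and on what is new or still open speak of the compounds shown alone.

Measured compounds:
compound 1, `Cn1nc(-c2ccccc2)c2c1OC(N)=C(C#N)C2c1cc(F)cc(F)c1`, 6600 nM
compound 2, `COc1ccc(C2C(C#N)=C(N)Oc3c2c(-c2ccccc2)nn3C)cc1`, a limit of > 10000 nM
compound 3, `Cc1nn(C)c2c1C(c1ccncc1)C(C#N)=C(N)O2`, 4100 nM

In a functional assay on NCI-H2122 cells (Homo sapiens) for inhibition, read by microscopy, with a stated time of 10 days (a higher number here means a weaker inhibitor, a lower number a stronger inhibitor), compound 1 gives 6600 nM. Compound 2 reaches only the limit of > 10000 nM in this assay, a limit and not a number. Compound 3 gives 4100 nM, the lowest of the two numbers shown, but its gap to compound 1 lies within the scatter, so no order between the two can be read. Going by the values given here, the single measured step, an at least 1.5-fold higher number from compound 1 to compound 2 (0.18 log units; that floor lies within the scatter), concerns the group on the saturated ring carbon and is capped by the limit of > 10000 nM in this assay, at which 1 of the 3 values shown sits.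

Compound 4, `Cn1nc(-c2ccccc2)c2c1OC(N)=C(C#N)C2c1ccncc1`, differs from compound 3 in one place: phenyl in place of methyl on an aromatic carbon. Among the compounds with values here, no measured step covers this change. Compounds 1 and 2 both carry the phenyl at that position, yet each differs from compound 4 on the saturated ring carbon too, so they speak to it only loosely. Compound 1 with the phenyl and compound 3 with the methyl sit within the scatter of each other, and on that ground no shift beyond the scatter is expected for a 1.5-fold higher number from compound 3 to compound 4 (0.17 log units; within the scatter). Compound 4 is accordingly estimated at 6000 nM, with a range from 2000 nM to 20000 nM.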

Compound 4, half-maximal inhibitory concentration: 5200 nM
Estimate against measurement, compound 4: 1.2-fold (0.06 log units) above; the measured number falls inside the stated range.
By their numbers in this assay, from the lowest: compounds 3, 4 and 1 (each within the scatter of the next). At a limit, above all of these: compound 2.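

In this assay, going by these compounds alone, the step of a 1.3-fold higher number from compound 3 to compound 4 (0.10 log units; within the scatter) gives the first direct reading of this position, and with pyridin-4-yl on the saturated ring carbon, methyl and phenyl on the aromatic carbon cannot be told apart. With the phenyl held in place, the step of a 1.3-fold lower number from compound 1 to compound 4 (0.10 log units; within the scatter) shows that pyridin-4-yl and 3,5-difluorophenyl on the saturated ring carbon cannot be told apart either. The step of an at least 1.9-fold lower number from compound 2 to compound 4 (0.28 log units; that floor lies within the scatter) rests on the limit of compound 2, not on a number, and so gives only a floor: the limit of > 10000 nM in this assay, at which 1 of the 4 values shown sits.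

On these data alone, it stays open whether another group on this aromatic carbon, such as an amine, a carboxylic acid or a longer alkyl chain, would give a number beyond the scatter from that of compound 3. As far as these compounds go, the comparison of methyl with phenyl is also read with pyridin-4-yl alone, so it remains unknown whether it would hold with 3,5-difluorophenyl or 4-methoxyphenyl on the saturated ring carbon.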